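Aryl urea in place of 5-oxopyrrolidinyl amide: compound 4

The compounds below may be only part of what the source reports. "The series", "measured", "known", "first", "only" and "open" are said of these compounds alone.

Measured compounds:
compound 1 `O=C1CC[C@@H](C(=O)N2CCN(c3nccc(Oc4cc(Cl)cc(Cl)c4)n3)CC2)N1`: > 50000 nM
compound 2 `O=S(=O)(c1ccccc1)N1CCN(c2nccc(Oc3cc(Cl)cc(Cl)c3)n2)CC1`: > 50000 nM
compound 3 `COc1ccc(S(=O)(=O)N2CCN(c3nccc(Oc4cc(Cl)cc(Cl)c4)n3)CC2)cc1`: 46800 nM

Of the compounds shown here, three sharing one core have been measured in a functional assay on MDA-MB-231 cells (Homo sapiens) for antiproliferative activity, read by MTT assay, with a stated time of 24 h; a higher number here means a weaker inhibitor, a lower number a stronger inhibitor. Compound 1 gives > 50000 nM, which is a limit of the assay and not a number. Compound 2 likewise gives > 50000 nM, again a limit. Compound 3 gives 46800 nM. The two limits are reflected in the limit of > 50000 nM in this assay, at which 2 of the 3 values shown sit. The step that the two limits leave unreadable from compound 1 to compound 2 is therefore unreadable, and the step of an at least 1.0-fold lower number from compound 2 to compound 3 (0.02 log units; that floor lies within the scatter) stays within the scatter. Compound 1 thus stands only at a limit, with no number of its own.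

Compound 4 `O=C(Nc1ccc(C(F)(F)F)cc1)N1CCN(c2nccc(Oc3cc(Cl)cc(Cl)c3)n2)CC1` differs from compound 1 by (4-(trifluoromethyl)phenyl)amino in place of 5-oxopyrrolidin-2-yl on a carbonyl carbon. Among the measured compounds shown here, of the measured steps, only the one from compound 1 to compound 2 alters the same position, and it is unreadable; the step from compound 2 to compound 3 shows no movement beyond the scatter. For the measured compounds named here, no measured step gives a direction for this change. The estimate for compound 4 is therefore 40000 nM, with a range from 10000 nM to 50000 nM, and the expected step is an at least 1.2-fold lower number from compound 1 to compound 4 (0.09 log units; that floor lies within the scatter), with a real chance that only a limit is reported.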

Compound 4, half-maximal inhibitory concentration: 1540 nM
For compound 4 the middle estimate is 26-fold (1.41 log units) above the measured one; measured number outside the range, below it.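

In this assay, putting (4-(trifluoromethyl)phenyl)amino in place of 5-oxopyrrolidin-2-yl on a carbonyl carbon whose other neighbour is an amide-type nitrogen in a ring gives an at least 32-fold lower number from compound 1 to compound 4 (1.51 log units; beyond the scatter), the only step among the compounds shown that is readable as lying beyond the scatter, so this position can carry a large change in antiproliferative read-out, which compounds 1, 2 and 3 could not show. Compound 1 gives > 50000 nM, which is a limit of the assay and not a number. The step from compound 1 is therefore a floor and its full size cannot be read, because one end of it rests on that limit: the limit of > 50000 nM in this assay, at which 2 of the 4 values shown sit.

The change swaps one whole group for another, so the compounds shown do not separate the part played by the trifluoromethyl from that of the aromatic ring or of the amino link. A nitrile or a chlorine in place of trifluoromethyl, or a cyclohexylamino group on the same carbonyl carbon, would begin to tell these parts apart.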